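A few compounds are considered here, and "the series" means these few. Any claim that something is new, unique, unknown or untested is made for them only; others in the source may bear on it.

Compound 1 `Cc1ccc(S(=O)(=O)NC(=O)Nc2ccccc2C(=O)/C=C/c2ccc(N(C)C)cc2)cc1` gives 38.1 ug/mL in an ADME assay on the whole organism for cytotoxicity, with Artemia salina as the target, with a stated time of 24 h; a lower number here means that less compound is needed, a higher number that more compound is needed for the effect.
Compound 2 `COc1ccc(/C=C/C(=O)c2ccccc2NC(=O)NS(=O)(=O)c2ccc(C)cc2)c(OC)c1` gives 16 ug/mL in this assay.

Among the measured compounds shown here, compound 2 has the lower of the two numbers; the only measured step, a 2.4-fold lower number from compound 1 to compound 2 (0.38 log units; beyond the scatter), separates it from compound 1. Compound 3 `Cc1ccc(S(=O)(=O)NC(=O)Nc2ccccc2C(=O)/C=C/c2ccccc2O)cc1` differs from compound 2 by 2-hydroxyphenyl in place of 2,4-dimethoxyphenyl on a double-bonded chain carbon bound to a double-bonded chain carbon. For the measured compounds named here, no measured step replaces this group in the same way, so that step serves only as a rough guide to how much such a change moves the number. For compound 3 a step of a 1.4-fold higher number from compound 2 to compound 3 (0.14 log units; within the scatter) is expected, within the scatter. Compound 3 is therefore estimated at 22 ug/mL, with a range from 9 ug/mL to 55 ug/mL.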

Compound 3, concentration for half-maximal effect: 32.3 ug/mL
The estimate for compound 3 lay 1.5-fold (0.17 log units) below the measured number; the range from low to high includes it.
By their numbers in this assay, from the lowest: compound 2; then compounds 3 and 1 (each within the scatter of the next).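

In this assay, the new change at this place, on a double-bonded chain carbon bound to a double-bonded chain carbon, gives a 2.0-fold higher number from compound 2 to compound 3 (0.31 log units; beyond the scatter) and is a second replacement of 2,4-dimethoxyphenyl that leaves compound 2 with the lowest number. The 2-hydroxyphenyl and 4-(dimethylamino)phenyl groups are not told apart, with a 1.2-fold lower number from compound 1 to compound 3 (0.07 log units; within the scatter) in this comparison. Nothing available explains these differences.

On these data alone, it remains open whether one methoxy group alone would keep the lower number of compound 2. As far as these compounds go, how a plain phenyl or a 4-chlorophenyl group would read at this place also stays open.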